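This account rests on a few compounds, and the source may have more. Where it says the series, first, only, none or still open, it means among the compounds named here.

In a functional assay on the whole organism (strain Kunming) with Mus musculus as the target, in the maximal electroshock model, with a stated time of 0.5 h (on this read-out lower numbers stand for an effect already at smaller amounts and higher numbers for an effect only at larger amounts of compound), compound 1 `O=C1NC2(CC2c2ccc3cccc(OCc4ccccc4)c3n2)C(=O)N1c1ccc(Cl)cc1` gives 300 mg/kg. Compound 2 `O=C1NC2(CC2c2ccc3cccc(OCc4ccccc4)c3n2)C(=O)N1c1ccc(F)cc1`, which carries fluoro in place of chloro on an aromatic carbon, gives 300 mg/kg in this assay, and the step of no change at the digits printed from compound 1 to compound 2 (within the scatter) leaves it level with compound 1 at the digits shown. Compound 3 `CCC(CO)N1C(=O)NC2(CC2c2ccc3cccc(OCc4ccccc4)c3n2)C1=O` differs from compound 2 in another way: 1-(hydroxymethyl)propyl in place of 4-fluorophenyl on an amide-type nitrogen in a ring. Among the measured compounds shown here, the only measured step, the halogen exchange from compound 1 to compound 2, does not touch the group on the ring nitrogen, so nothing measured here speaks directly to this change. For the measured compounds named here, with no step that bears on it, the expectation for compound 3 rests on the two measured values alone, and the step of no change at the digits printed from compound 2 to compound 3 (within the scatter) is estimated to stay within the scatter, in no particular direction. Compound 3 is therefore expected to give about 300 mg/kg in this assay, with a range from 100 mg/kg to 600 mg/kg.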

Compound 3, minimum effective dose: 30 mg/kg
The estimate for compound 3 lay 10-fold (1.00 log units) above the measured number, and the stated range ends above it.
By their numbers in this assay, from the lowest: compound 3; then compounds 1 and 2 (each within the scatter of the next).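

In the whole-organism read-out this assay, where the two halogen-bearing compounds could not be told apart, 1-(hydroxymethyl)propyl in place of 4-fluorophenyl on the amide-type nitrogen in a ring brings a 10-fold lower number from compound 2 to compound 3 (1.00 log units; beyond the scatter) and, in place of 4-chlorophenyl, a 10-fold lower number from compound 1 to compound 3 (1.00 log units; beyond the scatter) in the same assay. The number therefore responds to the group at this position, and compound 3 gives 30 mg/kg with no ring in that group at all. Nothing available accounts for this drop or ties it to one feature of the change.

The change removes the aromatic ring and brings in the hydroxyl at once, and the compounds shown do not separate these two parts. From the compounds shown here alone, a plain butyl chain would bear on that question, and an amine in place of the hydroxyl or a shorter 2-hydroxyethyl chain remains open as well.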